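Working notes: methoxy for tert-butyl in a small series

The compounds below may be only part of what the source reports. "The series", "measured", "known", "first", "only" and "open" are said of these compounds alone.

Measured so far in a functional assay on M21 cells (Homo sapiens) for antiproliferative activity, read by sulforhodamine B assay, with a stated time of 48 h; on this read-out higher numbers stand for weaker inhibition of growth and lower numbers for stronger inhibition of growth:
compound 1 `CC(C)(C)c1ccc(-c2cc(N3CCC(CNS(N)(=O)=O)CC3)ncn2)cc1` gives 19300 nM
compound 2 `COc1ccc(-c2cc(N3CCC(CNS(N)(=O)=O)CC3)ncn2)cc1` gives > 100000 nM
compound 3 `CC(C)(C)c1ccc(-c2cc(N3CCC(CCNS(N)(=O)=O)CC3)ncn2)cc1` gives 18400 nM

The value of compound 2 is a limit of this assay and not a number, as noted in the limit of > 100000 nM in this assay, at which 1 of the 3 values shown sits.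

Two changes are covered. From compound 1 to compound 2 the change is methoxy in place of tert-butyl on an aromatic carbon, and it gives an at least 5.1-fold higher number from compound 1 to compound 2 (0.71 log units; beyond the scatter). From compound 1 to compound 3 the change is (sulfamoylamino)methyl in place of sulfamoylamino on a saturated chain carbon bound to a saturated ring carbon, and it gives a 1.0-fold lower number from compound 1 to compound 3 (0.02 log units; within the scatter), so the two chain lengths cannot be told apart here.

Compound 4 `COc1ccc(-c2cc(N3CCC(CCNS(N)(=O)=O)CC3)ncn2)cc1` is not yet measured. It differs from compound 3 by methoxy in place of tert-butyl on an aromatic carbon; this is the same kind of change as the one from compound 1 to compound 2, made on the core of compound 3, whose difference from the core of compound 1 is the one described above. Within the data shown here, with only one measured example of the change, the expectation rests on that one step, and on the fact that the step from compound 1 to compound 3 is within the scatter, so the longer chain is not expected to alter the outcome.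

Compound 4 is therefore expected to follow the earlier step, with an estimated 6.0-fold higher number from compound 3 to compound 4 (0.78 log units; beyond the scatter). For compound 4 the estimate in this assay is 110000 nM, with a range from 60000 nM to 300000 nM, and it is likely that only a limit will be reported.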

Compound 4, concentration for 50% growth inhibition: 69800 nM
Beside the measured number, compound 4's estimate is 1.6-fold (0.20 log units) above it; measured number inside the range.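

In this assay, methoxy in place of tert-butyl on the core of compound 3 gives a 3.8-fold higher number from compound 3 to compound 4 (0.58 log units; beyond the scatter), so the direction of the change seen on the shorter chain carries over to the longer one: the same change on two cores in this assay, an at least 5.1-fold higher number (0.71 log units; beyond the scatter) from compound 1 to compound 2 and a 3.8-fold higher number (0.58 log units; beyond the scatter) from compound 3 to compound 4; the limit leaves it open whether they differ. The value of compound 2 is a limit of the assay and not a number, so these two cores show a shared direction but do not establish a shared size of the step: the limit of > 100000 nM in this assay, at which 1 of the 4 values shown sits. With methoxy in place, (sulfamoylamino)methyl in place of sulfamoylamino gives an at least 1.4-fold lower number from compound 2 to compound 4 (0.15 log units; that floor lies within the scatter), which does not show whether chain length matters in the methoxy pair as little as it does in the tert-butyl pair: the same change on two cores in this assay, a 1.0-fold lower number (0.02 log units; within the scatter) from compound 1 to compound 3 and an at least 1.4-fold lower number (0.15 log units; that floor lies within the scatter) from compound 2 to compound 4; the limit leaves it open whether they differ.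

From the compounds shown here alone, the series covers only two aromatic substituents and two chain lengths, so it remains open whether the step from tert-butyl would hold for other groups at that place, such as trifluoromethyl or a chlorine atom. Going by these compounds, it also remains open whether the same step would hold on a core with a longer chain, or with an amine or a carboxylic acid in place of the sulfamoylamino end.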